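A few compounds are considered here, and "the series" means these few. Any claim that something is new, unique, unknown or untested is made for them only; others in the source may bear on it.

Compound 1 `COc1cc(/C=C/c2nnc(NC(=O)c3ccccc3Br)s2)c(Br)c(OC)c1OC`: 370 nM
Compound 2 `COc1cc(/C=C/c2nnc(NC(=O)c3ccc(Br)cc3)s2)c(Br)c(OC)c1OC`: 320 nM

Both values come from a functional assay on MCF7 cells (Homo sapiens) for antiproliferative activity, read by MTT assay, with a stated time of 48 h; a higher number here means a weaker inhibitor, a lower number a stronger inhibitor. Going by the values given here, compound 2 stands level with compound 1, the only other measured compound, since a 1.2-fold lower number from compound 1 to compound 2 (0.06 log units; within the scatter) is no real separation. Compound 3 `COc1cc(/C=C/c2nnc(NC(=O)c3cccc(O)c3)s2)c(Br)c(OC)c1OC` keeps the shared core and has 3-hydroxyphenyl in place of 4-bromophenyl on a carbonyl carbon. Among the compounds with values here, only one measured step bears on this change, as it alters the group at the same place. That step, a 1.2-fold lower number from compound 1 to compound 2 (0.06 log units; within the scatter), is small, but it only exchanges one bromophenyl for another. Within the data shown here, no measured compound carries 3-hydroxyphenyl, so the evidence is indirect and the range must stay wide. A step beyond the scatter is not expected in this assay, and the expected step is a 1.3-fold higher number from compound 2 to compound 3 (0.10 log units; within the scatter). For compound 3 the estimated value is 400 nM, with an expected range of 120 nM to 1300 nM.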

Compound 3, half-maximal inhibitory concentration: 360 nM
Beside the measured number, compound 3's estimate is 1.1-fold (0.05 log units) above it; measured number inside the range.
By their numbers in this assay, from the lowest: compounds 2, 3 and 1 (each within the scatter of the next).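

Exchanging 4-bromophenyl for 3-hydroxyphenyl on the carbonyl carbon gives a 1.1-fold higher number from compound 2 to compound 3 (0.05 log units; within the scatter) in this assay, and exchanging 2-bromophenyl for 3-hydroxyphenyl gives a 1.0-fold lower number from compound 1 to compound 3 (0.01 log units; within the scatter) there. The earlier pair only moved from one bromophenyl to another, whereas these steps show that a group with oxygen instead of bromine, bringing a hydrogen-bond donor and acceptor, also leaves the number level at this place. Nothing available explains why the three compounds stand level.

The compounds shown leave open whether an amine, a carboxylic acid or a longer alkyl chain on the same carbonyl carbon would stay level with these three. They also cannot say whether a plain phenyl group there would separate from them in this assay or stand level too.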